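A few compounds are considered here, and "the series" means these few. Any claim that something is new, unique, unknown or untested is made for them only; others in the source may bear on it.

Measured so far:
Compound 1 `COc1cccc(-c2n[nH]cc2N2CCCNCC2)c1`: > 10000 nM
Compound 2 `COc1ccc(-c2n[nH]cc2N2CCNCC2)cc1`: 279 nM

Two compounds share the pyrazole core carrying a cyclic amine and an aromatic ring, and both have been tested in an assay on isolated protein for binding affinity to 5-hydroxytryptamine receptor 6 (Homo sapiens); a lower number here means a stronger inhibitor, a higher number a weaker inhibitor. Compound 1 `COc1cccc(-c2n[nH]cc2N2CCCNCC2)c1` gives only > 10000 nM in this assay, which is a limit of the assay and not a number. Compound 2 `COc1ccc(-c2n[nH]cc2N2CCNCC2)cc1` gives 279 nM in this assay. Compound 2 therefore carries the only number shown; the other entry is the limit of > 10000 nM in this assay, at which 1 of the 2 values shown sits.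

The next compound, compound 3 `Fc1ccc(-c2n[nH]cc2N2CCNCC2)cc1`, keeps everything of compound 2 except one change: fluoro in place of methoxy on an aromatic carbon. Among the measured compounds shown here, no measured pair differs in exactly this way, so there is no measured step to lean on. For a swap of this kind a shift of modest size in this assay is expected, most likely toward weaker binding but possibly within the usual scatter.

Compound 3 is estimated at 500 nM in this assay, with a range from 150 nM to 2000 nM. This estimate means an expected step of a 1.8-fold higher number from compound 2 to compound 3 (0.25 log units; within the scatter) in this assay.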

Compound 3, inhibition constant: 373 nM
For compound 3 the middle estimate is 1.3-fold (0.13 log units) above the measured one; measured number inside the range.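

Replacing methoxy with fluoro, on an aromatic carbon para to a large group, gives in this assay a 1.3-fold higher number from compound 2 to compound 3 (0.13 log units; within the scatter). Among the compounds shown here, this is the first measured step, and it shows that at this place the two groups cannot be told apart in this read-out, even though methoxy has 2 heavy atoms and 1 hydrogen-bond acceptor while fluoro has 1 heavy atom and 0 hydrogen-bond acceptors. So, for this one pair, neither the hydrogen-bond acceptor nor the extra heavy atom of methoxy is needed to keep the binding seen for compound 2, and nothing measured here offers a reason for that.

With only methoxy and fluoro shown at this place, it remains open whether a very different group there, such as an amine, a carboxylic acid or a longer chain like butoxy, would also leave the number within the scatter or would move it clearly. Going by these compounds, it also remains open whether the same swap would behave this way at another place on the aromatic ring, or on a compound with a different cyclic amine.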